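The compounds below may be only part of what the source reports. "The series", "measured", "known", "first", "only" and "open" are said of these compounds alone.

Compounds measured so far:
compound 1, `COc1cc(-c2nnc(SCC(=O)c3ccc(Cl)cc3)n2N2C(=O)c3ccccc3C2=O)cc(OC)c1OC`, 9030 nM
compound 2, `COc1cc(-c2nnc(SCC(=O)c3ccccc3)n2N2C(=O)c3ccccc3C2=O)cc(OC)c1OC`, > 200000 nM

In a functional assay on A549 cells (Homo sapiens) for cytotoxicity, read by MTT assay, with a stated time of 48 h (on this read-out higher numbers stand for weaker inhibition and lower numbers for stronger inhibition), compound 2 reaches a limit of the assay, (the limit of > 200000 nM in this assay, at which 1 of the 2 values shown sits), so no true number is known for it. Compound 3, `COc1cc(-c2nnc(SCC(=O)c3ccc(F)cc3)n2N2C(=O)c3ccccc3C2=O)cc(OC)c1OC`, differs from compound 2 by fluoro in place of hydrogen on an aromatic carbon. Among the compounds with values here, the one measured step of this kind, an at least 22-fold higher number from compound 1 to compound 2 (1.34 log units; beyond the scatter), was large; there a halogen was removed, here a different halogen enters at the same place. The expected change for compound 3 is a move back toward compound 1, an at least 3.3-fold lower number from compound 2 to compound 3 (0.52 log units; beyond the scatter), though with wide uncertainty. Compound 3 is therefore estimated at 60000 nM, between 10000 nM and 200000 nM.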

Compound 3, half-maximal inhibitory concentration: > 200000 nM
Compound 3 ended at the assay's limit (the forecaster's own chance of this, stated with the estimate: 30%); middle value at least 3.3-fold (0.52 log units) from the limit.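

Fluoro on this aromatic carbon, para to a large group, does not do what chloro does: putting fluoro in place of chloro gives an at least 22-fold higher number from compound 1 to compound 3 (1.34 log units; beyond the scatter). Among the three compounds, only the 4-chlorophenyl compound 1 gives a true number, so a halogen here is not enough on its own. The step between compound 2 and compound 3 cannot be read, because both values are limits: the limit of > 200000 nM in this assay, at which 2 of the 3 values shown sit.

As far as these compounds go, whether bromo, a methyl group or an amine on this same carbon would give a readable number stays open.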